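Nitrophenyl triazole in a coumarin cytotoxicity series

This account rests on a few compounds, and the source may have more. Where it says the series, first, only, none or still open, it means among the compounds named here.

Measured compounds:
compound 1 `O=c1ccc2cc(OCc3cc(-c4ccc([N+](=O)[O-])cc4)no3)ccc2o1`: 42200 nM
compound 2 `O=c1ccc2cc(OCc3cn(-c4cccc(CO)c4)nn3)ccc2o1`: "not determined" (no result reported)

Compound 2 stands without a number in a functional assay on HCT-116 cells (Homo sapiens) for cytotoxicity, read by MTT assay, with a stated time of 48 h (on this read-out higher numbers stand for weaker inhibition and lower numbers for stronger inhibition), so its position on this read-out cannot be placed. Compound 3 `O=c1ccc2cc(OCc3cn(-c4ccc([N+](=O)[O-])cc4)nn3)ccc2o1` differs from it by 4-nitrophenyl in place of 3-(hydroxymethyl)phenyl on an aromatic nitrogen. With no value for compound 2, no size or direction of step from it can be stated here. Among the compounds with values here, the only anchor is compound 1, which in this assay gives 42200 nM, a weak result. Compound 3 is expected to give a similarly weak value of 40000 nM, with a range from 12000 nM to 150000 nM.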

Compound 3, half-maximal inhibitory concentration: 44300 nM
Beside the measured number, compound 3's estimate is 1.1-fold (0.04 log units) below it; measured number inside the range.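

No step can be read between compound 2 and compound 3 in this assay. The compounds shown leave open what replacing 3-(hydroxymethyl)phenyl with 4-nitrophenyl does to this read-out. No supporting evidence bears on the result.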